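The source may report more compounds than this note shows. Statements on the series, on what has been measured and on what is new or still open speak of the compounds shown alone.

Measured in a functional assay on HL-60 cells (Homo sapiens) for inhibition, read by MTT assay, with a stated time of 72 h; a higher number here means a weaker inhibitor, a lower number a stronger inhibitor:
- compound 1 `Cc1nc(-c2ccccc2)c(C(=O)N2CCN(c3cccc(Cl)c3Cl)CC2)o1`: 133 nM
- compound 2 `Cc1nc(-c2ccc(F)cc2)c(C(=O)N2CCN(c3cccc(Cl)c3)CC2)o1`: 40.1 nM
- compound 3 `Cc1ccc(C)c(N2CCN(C(=O)c3oc(C)nc3-c3ccc(F)cc3)CC2)c1`: 358 nM

Compound 3 has the highest number of the three, at 358 nM, which makes it the weakest inhibitor so far in this assay. Compound 4 `Cc1ccc(C)c(N2CCN(C(=O)c3oc(C)nc3-c3ccccc3F)CC2)c1` differs from it by one change: 2-fluorophenyl in place of 4-fluorophenyl on an aromatic carbon. Within the data shown here, the only measured step, an 8.9-fold higher number from compound 2 to compound 3 (0.95 log units; beyond the scatter), was modest but beyond the scatter. It exchanged a different group, on an amine nitrogen in a ring, so it says little here. Among the measured compounds shown here, no measured pair moves the fluorine, so no shift beyond the scatter is expected, in either direction. The expected step, a 1.1-fold higher number from compound 3 to compound 4 (0.05 log units; within the scatter), is correspondingly small. For compound 4 the estimated value is 400 nM, with an expected range of 130 nM to 1200 nM.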

Compound 4, half-maximal inhibitory concentration: 319 nM
Beside the measured number, compound 4's estimate is 1.3-fold (0.10 log units) above it; low and high end bracket the measured number.
By their numbers in this assay, from the lowest: compound 2; then compound 1; then compounds 4 and 3 (each within the scatter of the next).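

Swapping 4-fluorophenyl for 2-fluorophenyl on this aromatic carbon gives a 1.1-fold lower number from compound 3 to compound 4 (0.05 log units; within the scatter) in this assay, so the two compounds cannot be told apart in this test. At least with the 2,5-dimethylphenyl group on the ring amine nitrogen, this assay does not distinguish these two fluorine placements. Nothing available explains this result.

From the compounds shown here alone, it remains open whether the same holds with the 3-chlorophenyl group of compound 2 in place of the 2,5-dimethylphenyl group. Also open, going by these compounds, is what a methoxy group or an amine would do in place of the fluorine.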